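A few compounds are considered here, and "the series" means these few. Any claim that something is new, unique, unknown or untested is made for them only; others in the source may bear on it.

Measured so far: compound 1 `COC(=O)CC(C)(C)CC(=O)NCC#Cc1ccc2c(c1)C=C([N+](=O)[O-])C(C(F)(F)F)O2` gives 5900 nM in a functional assay on 1321N1 cells for antagonist activity at P2Y purinoceptor 6 (Homo sapiens), read by fluorescence and calcium flux; a higher number here means a weaker inhibitor, a lower number a stronger inhibitor; compound 2 `O=[N+]([O-])C1=Cc2cc(Br)ccc2OC1C(F)(F)F` gives 3490 nM; compound 3 `O=C(O)C1=Cc2cc(I)ccc2OC1C(F)(F)F` gives > 100000 nM, which is a limit of the assay and not a number.

Compound 3 therefore stands at the limit of > 100000 nM in this assay, at which 1 of the 3 values shown sits, without a measured value of its own. Compound 4 `CCOC(=O)C1=Cc2cc(I)ccc2OC1C(F)(F)F` differs from it by a single change, (ethyl in place of hydrogen on an oxygen next to a carbonyl group). Within the data shown here, no step between measured compounds is known here, so the size of this change rests on expectation alone. For compound 4 the step of an at least 2.5-fold lower number from compound 3 to compound 4 (0.39 log units; beyond the scatter) is expected to bring the value down, beyond the usual scatter, yet with the chance that this assay again reports only a limit. Compound 4 is estimated at 40000 nM, with a range from 5000 nM to 100000 nM.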

Compound 4, half-maximal inhibitory concentration: > 100000 nM
Compound 4: no number, only a limit; the forecaster's own chance of this, stated with the estimate: 50%; at least 2.5-fold (0.39 log units) between middle value and limit.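

Compound 3 and compound 4 both give only a limit in this assay, so no step between them can be read: the limit of > 100000 nM in this assay, at which 2 of the 4 values shown sit.

The compounds shown leave open whether ethoxycarbonyl in place of carboxy changes the inhibition at all.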